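Swapping Nitro for Methoxy in an Antiproliferative Series

A few compounds are considered here, and "the series" means these few. Any claim that something is new, unique, unknown or untested is made for them only; others in the source may bear on it.

In a functional assay on MDA-MB-231 cells (Homo sapiens) for antiproliferative activity, read by MTT assay, with a stated time of 72 h (a higher number here means a weaker inhibitor, a lower number a stronger inhibitor), compound 3 `Cn1cc(-c2cnc3ncnc(NCc4cccc([N+](=O)[O-])c4)c3c2)cn1` gives > 100000 nM. That value is a limit and not a number, and it places compound 3 at the limit of > 100000 nM in this assay, at which 1 of the 3 values shown sits. Two relatives give numerical readings in this assay: compound 1 `COc1cccc(CNc2ncnc3ccc(-c4cnn(C)c4)cc23)c1` gives 28500 nM, and compound 2 `CC(Oc1nc(N)nc2ccc(-c3cnn(C4CCNCC4)c3)cc12)c1c(Cl)ccc(F)c1Cl` gives 7000 nM.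

The next compound, compound 4 `COc1cccc(CNc2ncnc3ncc(-c4cnn(C)c4)cc23)c1`, differs from compound 3 in one place, with methoxy in place of nitro on an aromatic carbon, meta to a large group (methoxy in place of nitro on an aromatic carbon). Among the compounds with values here, no measured pair isolates this change, so its size in this assay can only be expected. The estimated step of an at least 3.3-fold lower number from compound 3 to compound 4 (0.52 log units; beyond the scatter) points toward stronger inhibition. This expectation rests on compound 1, which also bears a methoxy group and gives 28500 nM. For compound 4 the expected value is 30000 nM, with an estimated range from 10000 nM to 90000 nM.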

Compound 4, half-maximal inhibitory concentration: > 100000 nM
Compound 4: only a limit was reported (the forecaster's own chance of this, stated with the estimate: 15%); middle value at least 3.3-fold (0.52 log units) from the limit.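

Compound 3 and compound 4 both stand at a limit in this assay and not at a number, so the step between them cannot be read: the limit of > 100000 nM in this assay, at which 2 of the 4 values shown sit.

The compounds shown leave open how far methoxy in place of nitro on an aromatic carbon shifts the reading.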